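The source may hold more compounds than are shown below. What is called first, only, known or untested is meant among the compounds shown, and "the series" means these compounds.

Working notes on the series. Going by the values given here, in an ADME assay on a cell-free system (plasma, Homo sapiens), read by HPLC, with a stated time of 120 min, at 37 degrees C (a higher number here means that more of the compound is left, a lower number that less of the compound is left), compound 2 `C[C@@H]1CN(C(=O)c2nc(Nc3cc(C4CC4)[nH]n3)c3cc(Cl)ccc3n2)CCN1C(=O)OCc1ccccc1` gives 86.2%, the higher of the two numbers so far, while compound 1 `CC(C)C(=O)OCOC(=O)N1CCN(C(=O)c2nc(Nc3cc(C4CC4)[nH]n3)c3cc(Cl)ccc3n2)C[C@H]1C` gives 6.1%. Compound 3 `C[C@@H]1CN(C(=O)c2nc(Nc3cc(C4CC4)[nH]n3)c3cc(Cl)ccc3n2)CCN1C(=O)OCC(Cl)(Cl)Cl` changes compound 2 in one place: trichloromethyl in place of phenyl on a saturated chain carbon bound to an oxygen next to a carbonyl group. Trichloromethyl stands in place of phenyl on a saturated chain carbon bound to an oxygen next to a carbonyl group. Among the compounds with values here, one measured step bears on this place: a number 80.1 percentage points higher from compound 1 to compound 2 (beyond the scatter), which is large and beyond the scatter. Within the data shown here, that step swaps (isopropylcarbonyl)oxy for phenyl, and no measured compound carries trichloromethyl, so it guides only loosely. Compound 3 has no (isopropylcarbonyl)oxy, so it is expected to lie nearer compound 2 at 86.2% than compound 1 at 6.1%. The expected change is a number 8.2 percentage points lower from compound 2 to compound 3 (within the scatter), a small fall near the scatter. For compound 3 the estimated value is 78%, with an expected range from 52% to 97%.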

Compound 3, percent of the compound remaining: 79%
Compound 3: the middle estimate sits 1 percentage points below what was measured; measured number inside the range.
By their numbers in this assay, from the lowest: compound 1; then compounds 3 and 2 (each within the scatter of the next).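

In this assay there is a number 7.2 percentage points lower from compound 2 to compound 3 (within the scatter) and so, on a saturated chain carbon bound to an oxygen next to a carbonyl group, trichloromethyl and phenyl cannot be told apart; a high number at this place therefore does not depend on a six-membered aromatic ring. Trichloromethyl also stands well clear of (isopropylcarbonyl)oxy (a number 72.9 percentage points higher from compound 1 to compound 3 (beyond the scatter)), so a second group now separates from the low number of compound 1. No measurement offered here explains these differences.

Open, from the compounds shown here alone, is whether the low number belongs to (isopropylcarbonyl)oxy alone or would return with another ester such as acetoxy. Also open, going by these compounds, is how a plain methyl, an amine or a carboxylic acid would read at this place.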